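Swapping a Methylsulfanyl Group on Two Acylated Cores

The compounds below may be only part of what the source reports. "The series", "measured", "known", "first", "only" and "open" are said of these compounds alone.

Compound 1 `CS/C(=N\C(=O)c1cc2ccccc2s1)NC(=O)c1cc2ccccc2s1` and compound 3 `CS/C(=N\C(=O)c1cc(-c2ccccc2)nc2ccccc12)NC(=O)c1cc(-c2ccccc2)nc2ccccc12` both carry a methylsulfanyl group on a central carbon with a double bond to nitrogen, but the larger parts attached to that carbon are not the same; the difference between the two cores is not broken down here. In a functional assay on K562 cells (Homo sapiens) for cytotoxicity, read by MTT assay, with a stated time of 72 h (on this read-out higher numbers stand for weaker inhibition of growth and lower numbers for stronger inhibition of growth), compound 1 gives 34700 nM and compound 3 gives 34400 nM. Compound 2 `O=C(/N=C(/NC(=O)c1cc(-c2ccccc2)nc2ccccc12)[Se]Cc1ccccc1)c1cc(-c2ccccc2)nc2ccccc12` is compound 3 after one change: a group of 8 heavy atoms (7 carbon, 1 selenium; one six-membered aromatic ring of carbon only) in place of a group of 2 heavy atoms (1 carbon, 1 sulfur; no ring), on a carbon with a double bond to nitrogen. In this assay compound 2 gives 9060 nM, so the step of a 3.8-fold lower number from compound 3 to compound 2 (0.58 log units; beyond the scatter) is a modest gain in growth inhibition. Compound 4 `O=C(/N=C(/NC(=O)c1cc2ccccc2s1)[Se]Cc1ccccc1)c1cc2ccccc2s1` is built from compound 1 by the same change, (a group of 8 heavy atoms (7 carbon, 1 selenium; one six-membered aromatic ring of carbon only) in place of a group of 2 heavy atoms (1 carbon, 1 sulfur; no ring), on a carbon with a double bond to nitrogen). Among the compounds with values here, because the step of a 3.8-fold lower number from compound 3 to compound 2 (0.58 log units; beyond the scatter) is the only record of this change, a step of similar size is expected for compound 4, a 3.7-fold lower number from compound 1 to compound 4 (0.56 log units; beyond the scatter). On that basis compound 4 is expected to give about 9500 nM in this assay, with a likely range from 4000 nM to 25000 nM.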

Compound 4, concentration for 50% growth inhibition: 14900 nM
Compound 4: middle estimate off by 1.6-fold (0.20 log units), on the low side; the range from low to high includes it.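

In this assay, replacing the methylsulfanyl group with the larger selenium-containing group again gives a modest gain in growth inhibition on this second core, with a 2.3-fold lower number from compound 1 to compound 4 (0.37 log units; beyond the scatter). The two records of this change point the same way, and their sizes do not differ by more than repeated measurements would allow: the same change on two cores in this assay, a 3.8-fold lower number (0.58 log units; beyond the scatter) from compound 3 to compound 2 and a 2.3-fold lower number (0.37 log units; beyond the scatter) from compound 1 to compound 4, 1.6-fold (0.21 log units) apart, within the scatter of two such steps

Two cores are still a small sample, so this does not show that the change would carry over to a third core, and the selenium atom and the six-membered aromatic ring enter together, so their separate shares in the step cannot be told apart. The compounds shown leave open how a sulfur atom carrying the same aromatic ring, or a selenium atom carrying only a methyl group, would compare on either core. Also open, on these data alone, is what an amine or a longer carbon chain would do on the carbon with a double bond to nitrogen in this assay.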